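Half-life notes: compound 2 to compound 4

This account rests on a few compounds, and the source may have more. Where it says the series, first, only, none or still open, it means among the compounds named here.

Three compounds of the series have numbers in an ADME assay on the whole organism for metabolic stability, with Rattus norvegicus as the target, at a dose of 2 mg/kg by the intravenous route; on this read-out higher numbers stand for a longer-lived compound and lower numbers for a shorter-lived compound. Compound 1 `COc1cc(C(=O)O)ccc1OCCCCOc1ccc(C(=O)CC(C)C)c(O)c1C` gives 0.467 h, compound 2 `Cc1c(OCCCCOc2ccc(C(=O)O)cc2)ccc(C(=O)CC(C)C)c1O` gives 0.5 h and compound 3 `COc1ccc(C(=O)O)cc1OCCCCOc1ccc(C(=O)CC(C)C)c(O)c1C` gives 0.95 h. Compound 2 stands within the scatter of both compound 1 and compound 3, so its number is not set apart from either of them.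

The next compound is compound 4 `Cc1c(OCCCCOc2ccc(F)c(C(=O)O)c2)ccc(C(=O)CC(C)C)c1O`, still to be measured in this assay. The change from compound 2 is 3-carboxy-4-fluorophenyl in place of 4-carboxyphenyl on an oxygen on a saturated carbon. In words, 3-carboxy-4-fluorophenyl comes in place of 4-carboxyphenyl on an oxygen on a saturated carbon.

Among the compounds with values here, only one measured step bears on this, and only loosely: a 1.1-fold higher number from compound 1 to compound 2 (0.03 log units; within the scatter), for hydrogen in place of methoxy on an aromatic carbon. That step is a different change and is small. No measured pair shows what this exchange of groups does to the half-life, so the data give no reason to expect a shift in either direction. No step beyond the scatter is therefore expected. The estimated step is a 1.2-fold higher number from compound 2 to compound 4 (0.08 log units; within the scatter).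

For compound 4 the expected half-life is 0.6 h, with an estimated range from 0.3 h to 1.2 h.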

Compound 4, half-life: 0.3 h
Compound 4: the middle estimate sits 2.0-fold (0.30 log units) above what was measured; measured number inside the range.
By their numbers in this assay, from the lowest: compounds 4, 1, 2 and 3 (each within the scatter of the next, the first and the last beyond it).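

Notes on compound 4: in this assay the exchange of 4-carboxyphenyl for 3-carboxy-4-fluorophenyl on an oxygen on a saturated carbon gives a 1.7-fold lower number from compound 2 to compound 4 (0.22 log units; within the scatter), so the half-life with the new group is not set apart from that with the old one. Within the data shown here, the earlier compounds offered only a 1.1-fold higher number from compound 1 to compound 2 (0.03 log units; within the scatter), a step at another place, so this is the only reading at this group, and it shows that this place accepts a fluorine and a different carboxy arrangement without a step beyond the scatter. No measurement at hand gives a reason for this number.

Among these compounds, the single step joins two differences, the added fluorine and the altered carboxy placement, so the share of each in the half-life stays open. Also open, as far as these compounds go, is how the half-life responds at this place to a group of another kind, such as chlorine in place of the fluorine or a tetrazole in place of the carboxylic acid, and whether a longer chain on the same oxygen would give a number beyond the scatter.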